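A few compounds are considered here, and "the series" means these few. Any claim that something is new, unique, unknown or untested is made for them only; others in the source may bear on it.

Measured so far:

Compound 1 `COc1ccc(-c2cnc(NC(=O)CCCCCCNC(=O)C(O)(O)C(F)(F)F)s2)cc1` gives 13000 nM in an assay on isolated protein for inhibition of histone deacetylase 8 (Homo sapiens), read by chemiluminescence, with a stated time of 3 h; a higher number here means a weaker inhibitor, a lower number a stronger inhibitor.
Compound 2 `COc1ccc(NC(=O)CCCCCCNC(=O)C(O)(O)C(F)(F)F)cc1` gives 51000 nM in this assay.
Compound 3 `COc1ccc2sc(NC(=O)CCCCCCNC(=O)C(O)(O)C(F)(F)F)nc2c1` gives 8900 nM in this assay.

All three share a long chain carrying the same metal-binding end group and differ only in the aromatic part attached to the amide. Among them compound 2 stands at the highest number, which means it is the weakest inhibitor of the three: compound 1 sits at a lower number, and compound 3 at a lower number still, and both of those gaps lie beyond the scatter of repeated measurements.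

The next compound, compound 4 `O=C(CCCCCCNC(=O)C(O)(O)C(F)(F)F)Nc1ccc(Cl)cc1`, keeps the whole chain of compound 2 and changes only one substituent on the aromatic ring: chloro in place of methoxy on an aromatic carbon. Going by the values given here, no measured pair shows this particular swap, so there is nothing in the data to calibrate it against. Both compound 2 and compound 4 carry a simple six-membered ring with a single small substituent, so the step is expected to be modest, within the scatter or only slightly beyond it, with a slight lean toward a lower number. The estimated step is a 1.3-fold lower number from compound 2 to compound 4 (0.11 log units; within the scatter), and compound 4 is therefore expected to show about 40000 nM, with a range from 15000 nM to 120000 nM.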

Compound 4, half-maximal inhibitory concentration: 52000 nM
Estimate against measurement, compound 4: 1.3-fold (0.11 log units) below; the measured number falls inside the stated range.
By their numbers in this assay, from the lowest: compounds 3 and 1 (each within the scatter of the next); then compounds 2 and 4 (each within the scatter of the next).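

Replacing methoxy with chloro on the aromatic ring, para to a large group, gives a 1.0-fold higher number from compound 2 to compound 4 (0.01 log units; within the scatter) in this assay, so this change leaves the two compounds indistinguishable. Compounds 1, 2 and 3 differ in the whole aromatic part attached to the amide, so they could not show what a single substituent on this ring contributes; this pair isolates one such change, and the hydrogen-bond acceptor counted on methoxy, absent from chloro, can go without a detectable shift in this one pair. Nothing measured here offers a reason for this match.

One exchange at one position cannot show whether this position is insensitive to substituents in general, since a primary amine, a carboxylic acid or a nitrile in the same place might still move the number well beyond the scatter. On these data alone, it also remains open whether chloro in place of methoxy would behave the same way on the aromatic parts of compound 1 or compound 3, or whether a longer chain would alter the picture.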